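Removing the chloro from the benzoyl of compound 1

The source may hold more compounds than are shown below. What is called first, only, known or untested is meant among the compounds shown, and "the series" means these compounds.

In a functional assay on NCI-H23 cells (Homo sapiens) for cytotoxicity, read by sulforhodamine B assay, with a stated time of 72 h (a lower number here means a stronger inhibitor of growth, a higher number a weaker inhibitor of growth), compound 1 `O=C(Nc1cc(C(F)(F)F)cc(C(F)(F)F)c1)C1CCc2ccccc2N1C(=O)c1ccccc1Cl` gives 2080 nM, the lowest of the two numbers at hand. Compound 3 `O=C(Nc1ccccc1O)c1ccc2ccccc2n1` gives 87500 nM, a gap from compound 1 that lies well beyond the scatter of the method. Compound 2 `CCCC(=O)N1c2ccccc2CCC1C(=O)Nc1ccccc1C(F)(F)F` returns only a limit of the method, > 70000 nM, which is not a number. That limit is the one at which a single value in this set stands, (the limit of > 70000 nM in this assay, at which 1 of the 3 values shown sits).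

Compound 4 `O=C(Nc1cc(C(F)(F)F)cc(C(F)(F)F)c1)C1CCc2ccccc2N1C(=O)c1ccccc1` has not been measured. It differs from compound 1 in one place: hydrogen in place of chloro on an aromatic carbon. For the measured compounds named here, no pair of measured compounds differs by this change alone, so its weight cannot be read from the series; compound 2 and compound 3 each differ from compound 1 at several places at once and say nothing about the chloro by itself. The change takes away one heavy atom and leaves the rest of the molecule untouched. A modest step, toward a higher number and close to the edge of the scatter, is expected, a 1.7-fold higher number from compound 1 to compound 4 (0.23 log units; within the scatter). Compound 4 is estimated at 3500 nM, with a range from 1000 nM to 12000 nM.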

Compound 4, concentration for 50% growth inhibition: 2130 nM
Compound 4: middle estimate off by 1.6-fold (0.22 log units), on the high side; low and high end bracket the measured number.
By their numbers in this assay, from the lowest: compounds 1 and 4 (each within the scatter of the next); then compound 3.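

In this assay, for the compounds shown here, the exchange of chloro for hydrogen on this aromatic carbon, ortho to a large group, gives the first step that can be read at a single place (a 1.0-fold higher number from compound 1 to compound 4 (0.01 log units; within the scatter)). The 2-chlorophenyl and the phenyl therefore read alike on this core, and the chloro is not required for growth inhibition at the level of compound 1. Compounds 2 and 3 could not show this, as each differs from compound 1 at several places at once, and no measurement at hand bears on the reason for the result.

Only chloro and hydrogen are shown at this carbon, so it remains open whether a methoxy, an amine or a carboxylic acid there would also read alike, and whether chloro on another carbon of the same ring would do so. Also open is what the two trifluoromethyl groups and the benzoyl as a whole contribute, as no pair shown changes either of them alone.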